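Furan-to-thiophene swap on the thiosemicarbazone aryl terminus

The compounds below may be only part of what the source reports. "The series", "measured", "known", "first", "only" and "open" are said of these compounds alone.

Measured compounds:
compound 1 `CC1=CC[C@H](C(C)(C)NC(=S)N/N=C/c2ccc(O)cc2)CC1`: 600 nM
compound 2 `CC1=CC[C@H](C(C)(C)NC(=S)N/N=C/c2ccco2)CC1`: 13500 nM

In a functional assay on PC-3 cells (Homo sapiens) for inhibition, read by sulforhodamine B assay, with a stated time of 48 h (a lower number here means a stronger inhibitor of growth, a higher number a weaker inhibitor of growth), compound 1 gives 600 nM and compound 2 gives 13500 nM. Compound 2 stands at the highest number of the two, with a 23-fold higher number from compound 1 to compound 2 (1.35 log units; beyond the scatter) separating it from compound 1.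

Compound 3 `CC1=CC[C@H](C(C)(C)NC(=S)N/N=C/c2cccs2)CC1` differs from compound 2 by thiophen-2-yl in place of furan-2-yl on a carbon with a double bond to nitrogen. Among the measured compounds shown here, no measured step covers a furan-to-thiophene exchange; the only step in hand, a 23-fold higher number from compound 1 to compound 2 (1.35 log units; beyond the scatter), concerns a different replacement at the same carbon and so bears on it only loosely. In this assay, compound 3 is therefore expected to sit close to compound 2, with a step of a 1.7-fold lower number from compound 2 to compound 3 (0.23 log units; within the scatter). The estimate for compound 3 is 8000 nM, within a range of 2500 nM to 25000 nM.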

Compound 3, concentration for 50% growth inhibition: 17800 nM
For compound 3 the middle estimate is 2.2-fold (0.35 log units) below the measured one; the measured number falls inside the stated range.
By their numbers in this assay, from the lowest: compound 1; then compounds 2 and 3 (each within the scatter of the next).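

In this assay, thiophen-2-yl in place of furan-2-yl on a carbon with a double bond to nitrogen gives a 1.3-fold higher number from compound 2 to compound 3 (0.12 log units; within the scatter), so the oxygen and sulfur versions of this five-membered aromatic ring cannot be told apart at this position. The gap to 4-hydroxyphenyl now appears with a second replacement, as a 30-fold higher number from compound 1 to compound 3 (1.47 log units; beyond the scatter), which leaves compound 1 alone at the low end of the three compounds, with both five-membered rings well above it. Nothing available accounts for either step.

Whether the gap follows the hydroxyl group or the phenyl ring itself remains open, as the compounds shown do not separate the two. An unsubstituted phenyl group, a 4-methoxyphenyl group or a 4-aminophenyl group on the same carbon would bear directly on that question.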